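Swapping the aryl group on a thiazolidinedione series

The source may report more compounds than this note shows. Statements on the series, on what has been measured and on what is new or still open speak of the compounds shown alone.

Measured compounds:
compound 1, `COc1cccc(/C=C2\SC(=O)N(Cc3ccc(C(=O)O)cc3)C2=O)c1`, 58000 nM
compound 2, `COc1ccc(/C=C2\SC(=O)N(Cc3ccc(C(=O)O)cc3)C2=O)cc1`, 48000 nM
compound 3, `O=C(O)c1ccc(CN2C(=O)S/C(=C\c3ccccn3)C2=O)cc1`, 90000 nM

Going by the values given here, in a functional assay on MCF7 cells (Homo sapiens) for cytotoxicity, read by MTT assay, with a stated time of 24 h (a higher number here means a weaker inhibitor, a lower number a stronger inhibitor), compound 2 gives the lowest of the three numbers, but the other two sit close to it: the move a 1.2-fold lower number from compound 1 to compound 2 (0.08 log units; within the scatter) and the move a 1.9-fold higher number from compound 2 to compound 3 (0.27 log units; within the scatter) both stay inside the scatter, so no compound can be called stronger or weaker than another on these data. The step now followed leads from compound 2 to compound 4, `O=C(O)c1ccc(CN2C(=O)S/C(=C\c3ccncc3)C2=O)cc1`, and consists of pyridin-4-yl in place of 4-methoxyphenyl on a double-bonded chain carbon bound to a double-bonded ring carbon.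

The nearest guide is the step from compound 2 to compound 3, where a pyridin-2-yl also replaced the 4-methoxyphenyl; that gave a 1.9-fold higher number from compound 2 to compound 3 (0.27 log units; within the scatter). The related move a 1.6-fold higher number from compound 1 to compound 3 (0.19 log units; within the scatter) points the same way and is equally small. Among the compounds with values here, only pyridin-2-yl has been tested as a ring with one hetero atom, so the pyridin-4-yl of compound 4 has no direct precedent, and the expectation is for a number near that of compound 2, possibly a little higher, within the scatter. Compound 4 is therefore expected to give 70000 nM, with a likely range from 30000 nM to 160000 nM, which would amount to an estimated step of a 1.5-fold higher number from compound 2 to compound 4 (0.16 log units; within the scatter).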

Compound 4, half-maximal inhibitory concentration: 84000 nM
Compound 4: middle estimate off by 1.2-fold (0.08 log units), on the low side; measured number inside the range.
By their numbers in this assay, from the lowest: compounds 2, 1, 4 and 3 (each within the scatter of the next).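

In this assay, the second pyridine tells the same story as the first: pyridin-4-yl in place of 4-methoxyphenyl stays within the scatter (a 1.8-fold higher number from compound 2 to compound 4 (0.24 log units; within the scatter)), and so does the same ring in place of 3-methoxyphenyl (a 1.4-fold higher number from compound 1 to compound 4 (0.16 log units; within the scatter)). The new information is that the two pyridines cannot be told apart (a 1.1-fold lower number from compound 3 to compound 4 (0.03 log units; within the scatter)), so moving from pyridin-2-yl to pyridin-4-yl produces no readable difference, and all four aromatic rings at this place on the double-bonded chain carbon remain within the scatter of one another in these steps. Nothing available explains why these swaps make so little difference to the read-out.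

Going by these compounds, what remains open is whether any group at this place can produce a step beyond the scatter, for example a 4-chlorophenyl, a 4-hydroxyphenyl, a phenyl carrying a dimethylamino group, or a non-aromatic cyclohexyl ring. Also open, on these data alone, is whether the number responds to a change elsewhere on the molecule, such as a methyl ester in place of the carboxylic acid that all four compounds share.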